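The compounds below may be only part of what the source reports. "The series", "measured", "known", "first", "only" and "open" are said of these compounds alone.

Of the compounds shown here, three built on one shared core have been measured in a functional assay on MCF7 cells (Homo sapiens) for cytotoxicity, read by MTT assay; a lower number here means a stronger inhibitor, a higher number a weaker inhibitor. Compound 1 `CC(=O)O[C@@H]1OC(=O)[C@](C)(C(C)=O)[C@@H]1C` gives 6000 nM in this assay. Compound 2 `CC(=O)[C@@]1(C)C(=O)O[C@@H](OC(=O)c2ccccc2)[C@H]1C` carries a phenyl in place of methyl on a carbonyl carbon and gives 3000 nM, so that a 2.0-fold lower number from compound 1 to compound 2 (0.30 log units; within the scatter). Compound 3 `CC(=O)O[C@@H]1OC(=O)[C@@](C)(C(C)=O)[C@@H]1C` differs from compound 1 only in configuration as drawn. For compound 3 this assay reports only a limit, > 10000 nM, and no number. The comparison an at least 1.6-fold higher number from compound 1 to compound 3 (0.22 log units; that floor lies within the scatter) thus rests on (the limit of > 10000 nM in this assay, at which 1 of the 3 values shown sits), and the place of compound 3 is known only as the weak end of the numbers shown.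

Compound 4 `CC(=O)O[C@@H]1OC(=O)[C@@](OC(C)=O)(C(C)=O)[C@@H]1C` differs from compound 3 by acetoxy in place of methyl on a saturated ring carbon. Among the measured compounds shown here, no measured step bears on this change: the one step that swaps groups does so on a carbonyl carbon and stays within the scatter, and the other alters only configuration. The step that the limit leaves unreadable from compound 3 to compound 4 is therefore expected to stay within the scatter of the limit. Compound 4 is estimated at 15000 nM, between 5000 nM and 50000 nM.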

Compound 4, half-maximal inhibitory concentration: > 50000 nM
Compound 4 ended at the assay's limit (the forecaster's own chance of this, stated with the estimate: 60%); middle value at least 3.3-fold (0.52 log units) from the limit.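

Among the compounds shown here, compound 3 and compound 4 both end at limits of this assay and not at numbers, so no step between them can be read. The compounds shown leave open whether acetoxy in place of methyl on a saturated ring carbon changes the number in this assay at all.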